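The source may report more compounds than this note shows. Statements on the series, on what has been measured and on what is new or still open speak of the compounds shown alone.

Measured so far in a functional assay on HEK293 cells (Homo sapiens) for cytotoxicity; a lower number here means that less compound is tolerated, a higher number that more compound is tolerated:
- compound 1 `COc1ccc([C@H]2CC(=O)N(Cc3cccc(N)c3)C2)cc1OC1CCCC1` gives > 10000 nM, a limit of the assay rather than a number.
- compound 2 `COc1ccc([C@H]2CC(=O)N(c3cccc(C#N)c3)C2)cc1OC1CCCC1` gives > 10000 nM, likewise a limit of the assay.
- compound 3 `COc1ccc([C@H]2CC(=O)N(c3ccc([S+](C)[O-])cc3)C2)cc1OC1CCCC1` gives 7510 nM.

Compound 2 thus stands at the limit of > 10000 nM in this assay, at which 2 of the 3 values shown sit, so only a limit and no number is known for it. Compound 4 `COc1ccc([C@H]2CC(=O)N(c3ccc(S(C)(=O)=O)cc3)C2)cc1OC1CCCC1` has not been measured. The change is 4-(methylsulfonyl)phenyl in place of 3-cyanophenyl on an amide-type nitrogen in a ring. The closest measured step is an at least 1.3-fold lower number from compound 2 to compound 3 (0.12 log units; that floor lies within the scatter), which also swaps the 3-cyanophenyl for a sulfur-bearing phenyl and stays within the scatter. The step that the two limits leave unreadable from compound 1 to compound 2 gives no readable size. No step beyond the scatter is therefore expected; the estimated step is an at least 1.2-fold lower number from compound 2 to compound 4 (0.09 log units; that floor lies within the scatter). Compound 4 is expected at 8000 nM, with a range from 4000 nM to 16000 nM.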

Compound 4, half-maximal cytotoxic concentration: > 10000 nM
Compound 4: no number, only a limit (the forecaster's own chance of this, stated with the estimate: 45%); at least 1.2-fold (0.09 log units) between middle value and limit.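

In this assay, 4-(methylsulfonyl)phenyl on the amide-type nitrogen behaves like 3-cyanophenyl and 3-aminobenzyl in giving no number, only a limit of the assay: the limit of > 10000 nM in this assay, at which 3 of the 4 values shown sit.

Changing only the sulfur-bearing group on the aromatic carbon gives an at least 1.3-fold higher number from compound 3 to compound 4 (0.12 log units; that floor lies within the scatter), so this change is not shown to matter. The steps between compounds that both sit at the limit cannot be read.

On these data alone, how far these compounds lie past the limit stays open. So does whether a carboxylic acid or a longer chain on that phenyl ring would give a number.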